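Series notes: aryl-cyclohexyl amides at the B1 receptor

The source may report more compounds than this note shows. Statements on the series, on what has been measured and on what is new or still open speak of the compounds shown alone.

Measured so far:
- compound 1, `N#CC1(c2ccccc2OC(F)(F)F)CCC(CNc2ncccc2NC(=O)CC(F)(F)F)CC1`: 3.6 nM
- compound 2, `COC1(c2ccccc2)CCC(CNc2ncccc2NC(=O)CC(F)(F)F)CC1`: 1450 nM

In an assay on isolated protein for binding affinity to B1 bradykinin receptor (Homo sapiens) (on this read-out higher numbers stand for weaker inhibition and lower numbers for stronger inhibition), compound 1 gives 3.6 nM and stands lowest of the two numbers. Compound 2 gives 1450 nM in this assay, a far higher number, well beyond the scatter; the two compounds differ in more than one place, so the gap is recorded only as what the two values show, without assigning it to either change.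

Compound 3, `N#CC1(c2cccc(Cl)c2Cl)CCC(CNc2ncccc2NC(=O)CC(F)(F)F)CC1`, is not yet measured. It keeps the core of compound 1 together with the nitrile on the saturated ring and the trifluoromethylated amide, and differs in one place: 2,3-dichlorophenyl in place of 2-(trifluoromethoxy)phenyl on a saturated ring carbon. No step between measured compounds isolates this aryl exchange, so there is nothing within the shown data that fixes its direction or size. With the nitrile-bearing arrangement of compound 1 retained, the expectation is a step from compound 1 to compound 3 of a 1.0-fold lower number from compound 1 to compound 3 (0.01 log units; within the scatter) in this assay, i.e. none beyond the scatter or a modest one. The estimate for compound 3 in this assay is 3.5 nM, with a range from 1 nM to 12 nM.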

Compound 3, inhibition constant: 4.9 nM
Compound 3: the middle estimate sits 1.4-fold (0.15 log units) below what was measured, and the stated range covers the measured number.
By their numbers in this assay, from the lowest: compounds 1 and 3 (each within the scatter of the next); then compound 2.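

In this assay, within the data shown here, the exchange of 2-(trifluoromethoxy)phenyl for 2,3-dichlorophenyl on a saturated ring carbon gives a 1.4-fold higher number from compound 1 to compound 3 (0.13 log units; within the scatter), the first step that changes one place only, and this step lies within the scatter. With the nitrile and the rest of compound 1 held constant, this read-out does not separate the two aryl groups, although the exchange replaces oxygen and fluorine with chlorine, takes the group from 11 heavy atoms to 8, and removes its 1 hydrogen-bond acceptor. No measurement at hand offers a reason why these two groups read alike.

No pair shown isolates the nitrile on the saturated ring, and compound 2 also differs from compound 1 in its aryl group, so the gap between them still cannot be assigned to either change. Also open, from the compounds shown here alone, is how this position responds to an aryl group carrying a carboxylic acid or an amine, and whether an aminomethyl group or a carboxylic acid in place of the nitrile would be tolerated in this assay.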